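From Fluoro to Carboxy on a Pyrrolidine Amide Chain

The compounds below may be only part of what the source reports. "The series", "measured", "known", "first", "only" and "open" are said of these compounds alone.

Three compounds have been measured so far:

compound 1, `O=C(CCCCCCc1ccccc1F)N1CCCC1`: 13700 nM
compound 2, `O=C(CCCCCCc1ccc(F)cc1)N1CCCC1`: 8000 nM
compound 3, `O=C(CCc1ccc(-c2ccc(Cl)cc2)cc1)N1CCCC1`: 48600 nM

All three were tested in an assay on HEK293 cells for inhibition of N-acylethanolamine-hydrolyzing acid amidase (Rattus norvegicus), read by LC-MS, with a stated time of 30 min; on this read-out lower numbers stand for stronger inhibition and higher numbers for weaker inhibition. Compound 2 shows the lowest number of the three, but compound 1 sits within the usual scatter of it, so these two cannot be told apart. Compound 3, which carries a different and shorter chain to a different aromatic part, lies clearly beyond the scatter and gives the weakest inhibition of the set.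

The next compound, compound 4, is `O=C(O)c1ccc(CCCCCCC(=O)N2CCCC2)cc1`. It keeps the whole core of compound 2 and changes only the group on the ring: carboxy in place of fluoro on an aromatic carbon. Within the data shown here, no measured pair in this set shows a change of this kind, so there is no step to lean on. The group that enters is larger than the one that leaves and brings a hydrogen-bond donor and acceptor where none stood, and the closest measured compounds carry only small, uncharged substituents on that ring. A moderate weakening, beyond the scatter, is therefore expected, though the direction is uncertain. For compound 4 the expected value in this assay is 25000 nM, with a range from 6000 nM to 100000 nM, which means an expected step of a 3.1-fold higher number from compound 2 to compound 4 (0.49 log units; beyond the scatter).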

Compound 4, half-maximal inhibitory concentration: > 100000 nM
Compound 4 gave a limit, no number (the forecaster's own chance of this, stated with the estimate: 25%); middle value at least 4.0-fold (0.60 log units) from the limit.
By their numbers in this assay, from the lowest: compounds 2 and 1 (each within the scatter of the next); then compound 3. At a limit, above all of these: compound 4.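

Among these compounds, this is the first step in the set that changes one place only, and in this assay it shows that the group on this aromatic carbon, para to a large group, can decide the outcome: carboxy in place of fluoro brings an at least 12-fold higher number from compound 2 to compound 4 (1.09 log units; beyond the scatter). Until now the only group seen on the ring of this chain was fluoro, in compounds 1 and 2, whose values lie within the scatter of each other, so nothing had shown that a change on the ring could matter this much. The value of compound 4 is a limit and not a number, so the true size of the step stays unknown: the limit of > 100000 nM in this assay, at which 1 of the 4 values shown sits.

Still open, going by these compounds, is whether the loss belongs to the carboxy group as a whole or to one part of it, which a methyl ester, a primary amide or a hydroxymethyl group at the same place could help separate. Also open, on these data alone, is whether an amine or a nitrile at that place would give the same result, and how a carboxylic acid would fare on the aromatic carbon where compound 1 carries its fluoro.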